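The source may hold more compounds than are shown below. What is called first, only, known or untested is meant among the compounds shown, and "the series" means these compounds.

Compound 1, `O=C(c1cccc(C#Cc2ccccc2Nc2ncnc3ccc(Cl)nc23)c1)N1CCOCC1`, is known in an assay on isolated protein for inhibition of MAP kinase-interacting serine/threonine-protein kinase 1 (Homo sapiens), read by HTRF, in the presence of a further agent that is not named here (a higher number here means a weaker inhibitor, a lower number a stronger inhibitor), only as a limit: compound 1 gives > 10000 nM, which is the limit of the assay rather than a number. Compound 2, `COC(=O)c1oc2ccc(Nc3ncnc4ccc(Cl)nc34)cc2c1C`, likewise gives only a limit in this assay, namely > 10000 nM. Both values sit at the limit of > 10000 nM in this assay, at which 2 of the 2 values shown sit. Compound 3, `CN(C)C(=O)c1cccc(C#Cc2ccccc2Nc2ncnc3ccc(Cl)nc23)c1`, differs from compound 1 by dimethylamino in place of morpholin-4-yl on a carbonyl carbon. Going by the values given here, no step between measured compounds is available, so the effect of this change is unknown; the expected step is a step that the limit leaves unreadable from compound 1 to compound 3, nothing beyond the usual scatter. Compound 3 is estimated at 15000 nM, in the range 5000 nM to 50000 nM.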

Compound 3, half-maximal inhibitory concentration: > 10000 nM
Compound 3: only a limit was reported; the forecaster's own chance of this, stated with the estimate: 80%; the middle value is on the limit's open side.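

In this assay, going by these compounds alone, compound 3 gives > 10000 nM, a limit rather than a number, so no step from compound 1 to compound 3 can be read. The compounds shown leave open whether dimethylamino or morpholin-4-yl on the carbonyl carbon makes any difference to inhibition.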